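Compound 3 and a hydroxymethyl swap

The source may report more compounds than this note shows. Statements on the series, on what has been measured and on what is new or still open speak of the compounds shown alone.

compound 1 `C=CCc1ccc(OCc2cn(-c3cccc([N+](=O)[O-])c3)nn2)c(O)c1` gives 15.2%
compound 2 `C=CCc1cc(O)c(O)c(CN2CCC(CCO)CC2)c1` gives 2.5%
compound 3 `C=CCc1ccc(OCc2cn(-c3ccc(C#N)cc3)nn2)c(O)c1` gives 1.5%
compound 4 `C=CCc1ccc(OCc2cn(-c3ccccc3CO)nn2)c(O)c1` is not yet measured

In a functional assay on HepG2 cells (Homo sapiens) for inhibition, read by MTT assay, with a stated time of 72 h, tested at 30 uM (a lower number here means less inhibition of growth, a higher number more inhibition of growth at the concentration tested), compound 3 gives 1.5%, a value within the scatter of compound 2 at 2.5% and beneath compound 1 at 15.2% by more than the scatter. Compound 4 has 2-(hydroxymethyl)phenyl in place of 4-cyanophenyl on an aromatic nitrogen. Among the measured compounds shown here, no measured pair here differs in one place only, so nothing sizes such a swap directly. All three measured values stay low, and compound 1 at 15.2% marks the top of them. The expected change is small, upward and within the scatter: a number 4.5 percentage points higher from compound 3 to compound 4 (within the scatter). For compound 4 the estimated value is 6%, with an expected range from 0% to 18%.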

Compound 4, percent growth inhibition at one concentration: 4.2%
Compound 4: the middle estimate sits 1.8 percentage points above what was measured; the measured number falls inside the stated range.
By their numbers in this assay, from the lowest: compounds 3, 2 and 4 (each within the scatter of the next); then compound 1.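

In this assay, placing 2-(hydroxymethyl)phenyl instead of 4-cyanophenyl on the aromatic nitrogen gives a number 2.7 percentage points higher from compound 3 to compound 4 (within the scatter). Among the compounds shown here, this is the first comparison here of compounds that differ in one place, and it does not separate them: swapping a nitrile-bearing ring for one with a hydrogen-bond donor leaves both numbers low. Nothing available explains this result. Still open, from the compounds shown here alone, is whether a phenyl ring carrying an amine, a carboxylic acid or a longer chain would give a number beyond the scatter.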